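From sec-butyl to allyl on the shared core

The source may hold more compounds than are shown below. What is called first, only, known or untested is meant among the compounds shown, and "the series" means these compounds.

Compound 1 (`CNc1nc(SC)nc2ncccc12`) gives 2920 nM
Compound 2 (`CSc1nc(NCC(C)C)c2cccnc2n1`) gives 540 nM
Compound 3 (`CCC(C)Nc1nc(SC)nc2ncccc12`) gives 860 nM

These values come from a functional assay (Nicotiana tabacum) (on this read-out lower numbers stand for stronger inhibition and higher numbers for weaker inhibition), where compound 3 stands within the scatter of compound 2, and well clear of compound 1. Compound 4 (`C=CCNc1nc(SC)nc2ncccc12`) puts allyl in place of sec-butyl on a nitrogen on an aromatic ring and changes nothing else. Two steps at that nitrogen bear on this. The step of a 3.4-fold lower number from compound 1 to compound 3 (0.53 log units; beyond the scatter) is modest, while a 1.6-fold higher number from compound 2 to compound 3 (0.20 log units; within the scatter) stays within the scatter. Allyl is a smaller group than sec-butyl but larger than methyl, so a small part of the first step may be lost. The expected step is a 1.6-fold higher number from compound 3 to compound 4 (0.21 log units; within the scatter) and points towards weaker inhibition, close to the edge of the scatter. Compound 4 is estimated at 1400 nM (range 650 nM to 2900 nM) in this assay when measured.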

Compound 4, half-maximal inhibitory concentration: 400 nM
Compound 4: the middle estimate sits 3.5-fold (0.54 log units) above what was measured; the measured number lies below the stated range.
By their numbers in this assay, from the lowest: compounds 4, 2 and 3 (each within the scatter of the next, the first and the last beyond it); then compound 1.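

In this assay, allyl, with 3 heavy atoms and a double bond outside aromatic rings, set against sec-butyl with 4 heavy atoms, does better on this nitrogen: a 2.2-fold lower number from compound 3 to compound 4 (0.33 log units; beyond the scatter). Among these compounds, the chain need not be branched, since a 1.4-fold lower number from compound 2 to compound 4 (0.13 log units; within the scatter), while the gain over methyl stays clear, with a 7.3-fold lower number from compound 1 to compound 4 (0.86 log units; beyond the scatter). Nothing measured here gives a reason for these steps.

Propyl, the saturated counterpart of allyl, would separate the double bond from chain length. Going by these compounds, how a longer chain or a chain ending in an amine would behave also stays open.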